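The source may report more compounds than this note shows. Statements on the series, on what has been measured and on what is new or still open speak of the compounds shown alone.

Measured compounds:
compound 1 `Cc1c(C)c2c(c(C)c1N)CC(C)(C)O2`, a functional assay on the whole organism with Mus musculus as the target (a higher number here means that more compound is needed for the effect, a lower number that less compound is needed), 7.8 mg/kg
compound 2 `Cc1c(N)c(C)c2c(c1CC(C)C)OC(C)(C)C2`, 13.3 mg/kg

Compound 1 has the lowest of the two numbers; its nearest neighbour is compound 2, and the step of a 1.7-fold higher number from compound 1 to compound 2 (0.23 log units; within the scatter) lies within the scatter. Compound 3 `Cc1c(C)c2c(c(C)c1N)CC(C)(CSCCC(=O)O)O2` differs from compound 1 by (2-carboxyethyl)sulfanyl in place of hydrogen on a saturated chain carbon bound to a saturated ring carbon. Within the data shown here, no measured step touches this place or this group; the one measured step, from compound 1 to compound 2, changes a different position and was within the scatter, so it gives little guidance. Among the measured compounds shown here, with no bearing step, the expectation for compound 3 is a moderate rise with wide uncertainty, estimated as a 1.5-fold higher number from compound 1 to compound 3 (0.19 log units; within the scatter). Compound 3 is therefore estimated at 12 mg/kg, ranging from 5 mg/kg to 30 mg/kg.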

Compound 3, dose for 50% inhibition: 43 mg/kg
Compound 3: middle estimate off by 3.6-fold (0.55 log units), on the low side; the whole stated range lies below it.
By their numbers in this assay, from the lowest: compounds 1 and 2 (each within the scatter of the next); then compound 3.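

In this assay, among these compounds, (2-carboxyethyl)sulfanyl in place of hydrogen on a saturated chain carbon bound to a saturated ring carbon gives a 5.5-fold higher number from compound 1 to compound 3 (0.74 log units; beyond the scatter) and is the only step beyond the scatter. This position therefore responds to substitution, and with this group more compound is needed for the effect. Nothing available explains the rise.

The compounds shown do not separate the contribution of the sulfur from that of the carboxylic acid or the chain. A methyl ester or a plain alkyl chain at this carbon would bear on that question.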